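Swapping the five-membered ring on a shared core

The compounds below may be only part of what the source reports. "The series", "measured", "known", "first", "only" and "open" are said of these compounds alone.

Measured compounds:
compound 1, `c1coc(-c2ccccc2OCC2=NCCN2)c1`, gives 1.26 nM in a functional assay for activation of Alpha-1A adrenergic receptor (Homo sapiens), read by calcium flux; on this read-out higher numbers stand for an effect only at larger amounts of compound and lower numbers for an effect already at smaller amounts
compound 2, `Cc1csc(-c2ccccc2OCC2=NCCN2)n1`, gives 25.1 nM in this assay

Going by the values given here, compound 2 stands at the higher of the two numbers measured so far, and its only neighbour is compound 1. Among the compounds with values here, the single measured step, a 20-fold higher number from compound 1 to compound 2 (1.30 log units; beyond the scatter), lies beyond the scatter, so exchanging one five-membered ring on the shared core for another has already moved the read-out a long way.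

Compound 3, `Cn1nccc1-c1ccccc1OCC1=NCCN1`, has not yet been measured. It differs from compound 2 by 1-methyl-1H-pyrazol-5-yl in place of 4-methyl-1,3-thiazol-2-yl on an aromatic carbon. Within the data shown here, the only step that bears on this change is a 20-fold higher number from compound 1 to compound 2 (1.30 log units; beyond the scatter): it shows that such a ring exchange can be large, but it involves a different pair of rings and gives no direction for the new one. A step of some size is therefore expected rather than none, and its direction is open.

Compound 3 is expected to give 8 nM in this assay, with a range from 1.5 nM to 50 nM. The expected step is a 3.1-fold lower number from compound 2 to compound 3 (0.50 log units; beyond the scatter).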

Compound 3, half-maximal effective concentration: 39.8 nM
The estimate for compound 3 lay 5.0-fold (0.70 log units) below the measured number; measured number inside the range.
By their numbers in this assay, from the lowest: compound 1; then compounds 2 and 3 (each within the scatter of the next).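

Placed on an aromatic carbon ortho to a group of 7 heavy atoms, 1-methyl-1H-pyrazol-5-yl and 4-methyl-1,3-thiazol-2-yl could not be told apart in this assay even though one ring holds sulfur where the other holds a second nitrogen, for the exchange gave a 1.6-fold higher number from compound 2 to compound 3 (0.20 log units; within the scatter) and so stayed within the usual scatter. The large step seen earlier is now joined by a second one, a 32-fold higher number from compound 1 to compound 3 (1.50 log units; beyond the scatter) and a 20-fold higher number from compound 1 to compound 2 (1.30 log units; beyond the scatter) together setting compound 1 apart from both methyl-bearing rings, so that at this position the furan-2-yl of compound 1 is what stands out, not one particular replacement. Nothing at hand gives a reason for this gap.

From the compounds shown here alone, whether the gap follows the methyl group or the ring itself stays open, as both rings that replace furan-2-yl carry a methyl group, and a furan-2-yl bearing a methyl group or a 1,3-thiazol-2-yl without one would separate the two. Equally open, going by these compounds, is how a six-membered ring such as phenyl or pyridinyl, or an open chain such as methoxy, would read at this place.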